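The source may hold more compounds than are shown below. What is called first, only, known or untested is meant among the compounds shown, and "the series" means these compounds.

Measured so far:
Compound 1 `CC1=C(C(=O)OC(C)C)C(C2CCCC2)N/C(=N/C#N)N1` gives 3% in an assay on HeLa cells for displacement of a labelled ligand from adenosine receptor A3 (Homo sapiens), with a stated time of 180 min, tested at 1 uM; on this read-out higher numbers stand for more inhibition at the one concentration tested (going by the name of the read-out) and lower numbers for less inhibition.
Compound 2 `CC1=C(C(=O)OC(C)C)C(C2CCCC2)NC(=O)N1` gives 7%.
Compound 3 `CCOC(=O)C1=C(C)N/C(=N\C#N)NC1C1CCCC1` gives 4%.

Compound 1 has the lowest of the three numbers, yet its gaps to compound 3 and to compound 2 are both within the scatter, so the three cannot be told apart. Compound 4 `CC1=C(C(=O)OC(C)C)C(c2ccoc2)N/C(=N/C#N)N1` differs from compound 1 by furan-3-yl in place of cyclopentyl on a saturated ring carbon. Among the measured compounds shown here, the only measured step, a number 1 percentage points higher from compound 1 to compound 3 (within the scatter), alters a different part of the shared molecule, and the difference between compound 2 and compound 1 is likewise unrelated, so no measured step bears on the present change. With nothing to go on, the expected step is a number 2 percentage points higher from compound 1 to compound 4 (within the scatter), none beyond the scatter. Compound 4 is therefore estimated at 5%, with a range from -5% to 15%.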

Compound 4, a percentage reported as inhibition, at one concentration (the size of the read-out at that concentration, not a potency): 41%
Beside the measured number, compound 4's estimate is 36 percentage points below it; the measured number lies above the stated range.
By their numbers in this assay, from the lowest: compounds 1, 3 and 2 (each within the scatter of the next); then compound 4.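

Among the compounds shown here, the saturated ring carbon bearing cyclopentyl is a position that matters in this assay: furan-3-yl in place of cyclopentyl gives a number 38 percentage points higher from compound 1 to compound 4 (beyond the scatter), whereas the one step measured elsewhere on the molecule gives a number 1 percentage points higher from compound 1 to compound 3 (within the scatter). The two groups have the same count of heavy atoms, so that count alone does not separate them; one is an aromatic ring with a ring oxygen, the other a carbon-only saturated ring. Nothing available explains this rise. Still open, from the compounds shown here alone, is whether the aromatic ring or its oxygen matters more, and how a phenyl or thiophen-3-yl group would read at this carbon.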